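Propylsulfonyl for cyclopropylcarbonyl on the ring nitrogen

The source may hold more compounds than are shown below. What is called first, only, known or untested is meant among the compounds shown, and "the series" means these compounds.

Within the data shown here, compound 1 `O=C(Nc1ccc(C(F)(F)F)cc1)NC1CCN(C(=O)C2CC2)CC1` is the only member of this series with a number in a physicochemical assay for lipophilicity, using the shake flask method (on this read-out higher numbers stand for higher lipophilicity and lower numbers for lower lipophilicity), where compound 1 gives 3.18. Compound 2 `CCC(C)C(=O)N1CCC(NC(=O)NC2CCCCC2)CC1` has no result in this assay, with the entry for compound 2 standing as "not determined" (no result reported). Compound 3 `CCC(C)C(=O)N1CCC(NC(=O)NC2CCCCCC2)CC1` likewise carries no number, its entry in this assay for compound 3 being "not determined" (no result reported). Among the measured compounds shown here, no step between two measured compounds can therefore be taken from the series; compound 1 stands alone as the anchor.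

Compound 4 `CCCS(=O)(=O)N1CCC(NC(=O)Nc2ccc(C(F)(F)F)cc2)CC1` is the next member to be measured in this assay. Compared with compound 1, the change is propylsulfonyl in place of cyclopropylcarbonyl on an amine nitrogen in a ring. The amide and urea parts of the shared core are untouched, and the aryl group bearing trifluoromethyl stays in place.

With only compound 1 as a reference, the step is expected to be small and not beyond the scatter, perhaps leaning slightly downward, so a number 0.13 log units lower from compound 1 to compound 4 (within the scatter) is the expected step. For compound 4 the estimated value in this assay is 3.05, with a range from 2.55 to 3.55.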

Compound 4, partition coefficient: 3.39
For compound 4 the middle estimate is 0.34 log units below the measured one; the measured number falls inside the stated range.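

In this assay, among these compounds, propylsulfonyl in place of cyclopropylcarbonyl on the amine nitrogen in a ring gives a number 0.21 log units higher from compound 1 to compound 4 (within the scatter), the first step that can be read. At this position, the exchange of a three-membered ring of carbon only for an open chain, with a sulfur and one more hydrogen-bond acceptor entering, therefore leaves the two values within the scatter of each other. Nothing at hand gives a reason for this outcome.

From the compounds shown here alone, whether the same would hold for methylsulfonyl, a longer chain on the sulfonyl or a carboxylic acid at this nitrogen stays open. Among the compounds shown here, compound 2 and compound 3 carry no number in this assay, so no step to either can be read, and this single pair gives no pattern for the series.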